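Benzylic urea series: half-life notes toward compound 4

The source may hold more compounds than are shown below. What is called first, only, known or untested is meant among the compounds shown, and "the series" means these compounds.

Measured so far in a physicochemical assay for pharmacokinetics; on this read-out lower numbers stand for a shorter-lived compound and higher numbers for a longer-lived compound:
compound 1, `O=C(NCC1CCCCC1)N1C(=O)c2ccccc2S1(=O)=O`: 0.963 h
compound 2, `Cc1ccccc1CNC(=O)N1C(=O)c2ccccc2S1(=O)=O`: 0.792 h
compound 3, `O=C(NCc1ccccc1F)N1C(=O)c2ccccc2S1(=O)=O`: 0.598 h

All three numbers sit within the usual scatter of one another: a 1.2-fold lower number from compound 1 to compound 2 (0.08 log units; within the scatter), a 1.6-fold lower number from compound 1 to compound 3 (0.21 log units; within the scatter) and a 1.3-fold lower number from compound 2 to compound 3 (0.12 log units; within the scatter). Compound 3 is therefore not separated from either of the other two in this assay; the three values read as one level.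

Compound 4 is `COc1cccc(CNC(=O)N2C(=O)c3ccccc3S2(=O)=O)c1`. Against compound 3 the change is 3-methoxyphenyl in place of 2-fluorophenyl on a saturated chain carbon bound to an amide-type nitrogen. Two kinds of measured step speak to it. Exchanging one substituent for another on the aryl ring, a 1.3-fold lower number from compound 2 to compound 3 (0.12 log units; within the scatter), stayed within the scatter, and so did both exchanges of cyclohexyl for a substituted phenyl, a 1.2-fold lower number from compound 1 to compound 2 (0.08 log units; within the scatter) and a 1.6-fold lower number from compound 1 to compound 3 (0.21 log units; within the scatter). Within the data shown here, a methoxy substituent and the 3-methoxyphenyl pattern have no measured precedent, so the expectation rests only on the observation that no change tried so far moved this assay beyond its scatter.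

The step to compound 4 is accordingly expected to be a 1.2-fold higher number from compound 3 to compound 4 (0.07 log units; within the scatter), that is, no shift beyond the scatter. Compound 4 is estimated at 0.7 h, with a range from 0.35 h to 1.4 h.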

Compound 4, half-life: 0.523 h
Compound 4: middle estimate off by 1.3-fold (0.13 log units), on the high side; measured number inside the range.
By their numbers in this assay, from the lowest: compounds 4, 3, 2 and 1 (each within the scatter of the next).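

In this assay, 3-methoxyphenyl on a saturated chain carbon bound to an amide-type nitrogen carries a hydrogen-bond acceptor where 2-fluorophenyl carries none, and it has 8 heavy atoms against 7, yet the exchange gives a 1.1-fold lower number from compound 3 to compound 4 (0.06 log units; within the scatter). The same group also stays within the scatter against the other two groups at this place, with a 1.5-fold lower number from compound 2 to compound 4 (0.18 log units; within the scatter) and a 1.8-fold lower number from compound 1 to compound 4 (0.27 log units; within the scatter), so the four compounds read as one level and this place has not yet shown a separable response in this assay, even with an oxygen-bearing substituent on the aryl ring. No supporting measurement is available to explain why the numbers stay level.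

Going by these compounds, whether an amine or a carboxylic acid on the aryl ring, or a longer chain at this place, would move this assay beyond the scatter remains open. All four compounds also share one core, so they cannot tell how this assay would respond to a change anywhere other than this place.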